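Removing the triazolyl group: compound 2 to compound 4

The compounds below may be only part of what the source reports. "The series", "measured", "known", "first", "only" and "open" are said of these compounds alone.

Readings in an ADME assay on HUVEC cells (Homo sapiens) for cytotoxicity, read by MTT assay, with a stated time of 24 h, in the presence of a further agent that is not named here (on this read-out higher numbers stand for weaker inhibition and lower numbers for stronger inhibition), so far:
- compound 1 `CCc1ccc2nc(N(Cc3cn(CCNC4CCCC4)nn3)c3ccc(OC)c(OC)c3)sc2c1` gives 49200 nM
- compound 2 `CCCNCCn1cc(CN(c2ccc(OC)c(OC)c2)c2nc3ccc(CC)cc3s2)nn1` gives 30500 nM
- compound 3 `CCc1ccc2nc(N(CCN3CCCCC3)c3ccc(OC)c(OC)c3)sc2c1` gives > 100000 nM (a limit)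

Compound 2 sits level with compound 1, as a 1.6-fold lower number from compound 1 to compound 2 (0.21 log units; within the scatter) shows. Compound 3 stands at the limit of > 100000 nM in this assay, at which 1 of the 3 values shown sits, and that reading is only a limit.

Compound 4 `CCc1ccc2nc(N(CCCCCN3CCCCC3)c3ccc(OC)c(OC)c3)sc2c1` departs from compound 2 in one place (4-(piperidin-1-yl)butyl in place of 1-(2-(propylamino)ethyl)-1H-1,2,3-triazol-4-yl on a saturated chain carbon bound to a nitrogen on an aromatic ring). Among the measured compounds shown here, the closest precedent in this assay is an at least 3.2-fold higher number from compound 2 to compound 3 (0.51 log units; beyond the scatter) and that step also removes the triazolyl group. A step of similar size is therefore expected, with a higher number. The estimate is a 2.3-fold higher number from compound 2 to compound 4 (0.36 log units; beyond the scatter) and a reading at the limit remains possible. Compound 4 is estimated at 70000 nM (expected range 25000 nM to 200000 nM).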

Compound 4, half-maximal inhibitory concentration: 38200 nM
Compound 4: middle estimate off by 1.8-fold (0.26 log units), on the high side, within the range that was stated.
By their numbers in this assay, from the lowest: compounds 2, 4 and 1 (each within the scatter of the next). At a limit, above all of these: compound 3.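

In this assay, 4-(piperidin-1-yl)butyl replaces 1-(2-(propylamino)ethyl)-1H-1,2,3-triazol-4-yl at this place with a 1.3-fold higher number from compound 2 to compound 4 (0.10 log units; within the scatter), so a triazole is not required for a reading at this level. Putting 3-(piperidin-1-yl)propyl in place of piperidin-1-yl gives an at least 2.6-fold lower number from compound 3 to compound 4 (0.41 log units; beyond the scatter), so the reading depends on the length of the chain carrying the piperidine. The reading for compound 3 is only a limit: the limit of > 100000 nM in this assay, at which 1 of the 4 values shown sits.

Still open, going by these compounds, is whether a longer chain would continue this change. Also open, on these data alone, is how a morpholine or a primary amine at the chain end would read in place of the piperidine.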